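This account rests on a few compounds, and the source may have more. Where it says the series, first, only, none or still open, it means among the compounds named here.

Compound 1 `Cc1cccc(NC(=S)OCCc2ccccn2)c1` carries a methyl on its aromatic ring. In an ADME assay on MT4 cells (Homo sapiens) for cytotoxicity, read by MTT assay (a higher number here means that more compound is tolerated, a lower number that less compound is tolerated), compound 1 gives > 100000 nM, which is a limit of the assay and not a number. Compound 2 `S=C(Nc1cccc(Cl)c1)OCCc1ccccn1` differs from compound 1 in one place (chloro in place of methyl on an aromatic carbon). In this assay compound 2 gives 47000 nM. The measured step is an at least 2.1-fold lower number from compound 1 to compound 2 (0.32 log units; beyond the scatter), and it is given as a bound rather than a fixed size because the limit of > 100000 nM in this assay, at which 2 of the 3 values shown sit, is where compound 1 sits.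

Compound 3 `Cc1ccc(NC(=S)OCCc2ccccc2)cc1` carries the same methyl on a different core; the difference between the two cores is not broken down here. In this assay compound 3 gives > 100000 nM, again a limit of the assay and not a number.

Compound 4 `S=C(Nc1ccc(Cl)cc1)OCCc1ccccc1` is still to be measured in this assay. It differs from compound 3 by one change (chloro in place of methyl on an aromatic carbon). This is the same kind of change as from compound 1 to compound 2, not the same change: there the place is meta to a large group, here it is para to a large group, and the core is another one. Within the data shown here, the expectation for compound 4 rests on an at least 2.1-fold lower number from compound 1 to compound 2 (0.32 log units; beyond the scatter), the only measured instance of this change. The step from compound 3 to compound 4 is expected to be an at least 1.6-fold lower number from compound 3 to compound 4 (0.22 log units; that floor lies within the scatter). Compound 4 is expected to give 60000 nM in this assay, most likely between 25000 nM and 150000 nM, with a real chance that only a limit is reported.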

Compound 4, half-maximal cytotoxic concentration: > 100000 nM
Compound 4: a limit, no number (the forecaster's own chance of this, stated with the estimate: 40%); middle value at least 1.6-fold (0.22 log units) from the limit.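

In this assay compound 4 gives > 100000 nM, a limit of the assay and not a number. Compound 3 is also a limit, so the step from one to the other cannot be read; both sit at this value: the limit of > 100000 nM in this assay, at which 3 of the 4 values shown sit.

Going by these compounds, whether chloro in place of methyl on an aromatic carbon changes the number at all on the core of compound 3 stays open.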